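The compounds below may be only part of what the source reports. "The series", "measured", "known", "first", "only" and "open" are said of these compounds alone.

Compound 1 `CCOc1ccc(-c2c(NC(=O)c3ccccc3)c(C(=O)O)nn2-c2ccc(Oc3ccccc3)cc2)cc1` gives 1130 nM in an assay for displacement of a labelled ligand from E3 ubiquitin-protein ligase Mdm2 (Homo sapiens), read by fluorescence polarization, with a stated time of 30 min; a higher number here means a weaker inhibitor, a lower number a stronger inhibitor. Compound 2 `CCOc1ccc(-c2c(NC(=O)c3ccc(OC(C)C)cc3)c(C(=O)O)nn2-c2ccc(Oc3ccccc3)cc2)cc1` gives 301 nM, and compound 3 `CCOc1ccc(-c2c(NC(=O)c3ccc(OCC(C)C)cc3)c(C(=O)O)nn2-c2ccc(Oc3ccccc3)cc2)cc1` gives 446 nM, the second highest of the three numbers. The measured steps all concern one other part of the shared core: a 3.8-fold lower number from compound 1 to compound 2 (0.57 log units; beyond the scatter), a 2.5-fold lower number from compound 1 to compound 3 (0.40 log units; beyond the scatter), and a 1.5-fold higher number from compound 2 to compound 3 (0.17 log units; within the scatter). Compound 4 `CC(C)COc1ccc(C(=O)Nc2c(C(=O)O)nn(-c3ccc(Oc4ccccc4)cc3)c2-c2ccc(OC(C)C)cc2)cc1` differs at a different place: methyl in place of hydrogen on a saturated chain carbon bound to an oxygen on an aromatic ring and a saturated chain carbon. For the measured compounds named here, no measured step touches this part of the molecule, so the known steps bear on it only indirectly, and the one single-carbon change among them, from compound 2 to compound 3, stayed within the scatter. Compound 4 is therefore expected to show a step of a 1.0-fold higher number from compound 3 to compound 4 (0.00 log units; within the scatter), nothing beyond the scatter. The estimate for compound 4 is 450 nM, with a range from 200 nM to 1000 nM.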

Compound 4, inhibition constant: 422 nM
The estimate for compound 4 lay 1.1-fold (0.03 log units) above the measured number; low and high end bracket the measured number.
By their numbers in this assay, from the lowest: compounds 2, 4 and 3 (each within the scatter of the next); then compound 1.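

For the compounds shown here, this is the first measured change at this position, where the ethoxy on the 4-ethoxyphenyl group becomes isopropoxy, and in this assay it gives a 1.1-fold lower number from compound 3 to compound 4 (0.02 log units; within the scatter) and so no real difference. An added methyl on this saturated chain carbon is therefore tolerated in this series, at least with the isobutoxy group held fixed elsewhere on the molecule. Nothing available explains why the number holds steady. The compounds shown leave open whether a longer chain such as butoxy, or an amine in place of the ethoxy, would be tolerated equally well.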